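Two methoxy groups added to compound 2's aryl ring

The source may report more compounds than this note shows. Statements on the series, on what has been measured and on what is new or still open speak of the compounds shown alone.

Measured compounds:
Compound 1 `COc1cc(/C=C/C(=O)c2ccc(OCCSC(=S)N3CCN(C)CC3)cc2)cc(OC)c1OC` — 10000 nM
Compound 2 `COc1ccc(/C=C/C(=O)c2ccc(OCCCSC(=S)N3CCN(C)CC3)cc2)cc1` — > 100000 nM
Compound 3 `O=C(/C=C/c1cccs1)c1ccc(OCCSC(=S)N2CCCC2)cc1` — 18300 nM

In a functional assay on ECa-109 cells for inhibition, with ECa-109 cell line (Homo sapiens) as the target, read by MTT assay, with a stated time of 72 h (on this read-out lower numbers stand for stronger inhibition and higher numbers for weaker inhibition), compound 1 gives 10000 nM, and compound 3 gives 18300 nM. Compound 2 reaches only a limit of this assay, > 100000 nM, so its place among the numbers is open: it sits at the limit of > 100000 nM in this assay, at which 1 of the 3 values shown sits, and no exact number is known for it.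

The piece follows the step from compound 2 to the unmeasured compound 4 `COc1cc(/C=C/C(=O)c2ccc(OCCCSC(=S)N3CCN(C)CC3)cc2)cc(OC)c1OC`. The change is 3,4,5-trimethoxyphenyl in place of 4-methoxyphenyl on a double-bonded chain carbon bound to a double-bonded chain carbon. Compound 4 thereby carries the same aryl group as compound 1, which in this assay gives 10000 nM, while its chain to the dithiocarbamate is that of compound 2. Among the measured compounds shown here, no measured pair shows this change on its own, so the expected size of the step rests on compound 1 alone.

The author expects that the step from compound 2 to compound 4, an at least 5.0-fold lower number from compound 2 to compound 4 (0.69 log units; beyond the scatter), is a move toward stronger inhibition, beyond the scatter. Compound 4 is estimated at 20000 nM in this assay, with a range from 5000 nM to 100000 nM.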

Compound 4, half-maximal inhibitory concentration: 7430 nM
Beside the measured number, compound 4's estimate is 2.7-fold (0.43 log units) above it; measured number inside the range.
By their numbers in this assay, from the lowest: compounds 4, 1 and 3 (each within the scatter of the next, the first and the last beyond it). At a limit, above all of these: compound 2.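

In this assay, putting 3,4,5-trimethoxyphenyl in place of 4-methoxyphenyl on a double-bonded chain carbon bound to a double-bonded chain carbon gives an at least 13-fold lower number from compound 2 to compound 4 (1.12 log units; beyond the scatter), and this is the one pair shown that isolates this change, with the chain and the N-methylpiperazine-bearing dithiocarbamate end left the same. The size of that step is a bound and not an exact figure, since compound 2 stands at a limit of the assay: the limit of > 100000 nM in this assay, at which 1 of the 4 values shown sits.

With the 3,4,5-trimethoxyphenyl group held constant, the change in the chain gives a 1.3-fold lower number from compound 1 to compound 4 (0.13 log units; within the scatter), so in this assay the group of 11 heavy atoms and the group of 10 heavy atoms cannot be told apart, and the aryl change alone carries compound 4 to the level of compound 1.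

The compounds shown leave open whether a 3,4-dimethoxyphenyl group would bring the same step, and whether a longer chain to the dithiocarbamate would still keep the level of compound 1 and compound 4. Compound 3 differs from these compounds in more than one place, so it offers no direct comparison with them.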